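This account rests on a few compounds, and the source may have more. Where it says the series, first, only, none or still open, it means among the compounds named here.

In a functional assay on the whole organism for agonist activity, with Mus musculus as the target (a higher number here means that more compound is needed for the effect, a lower number that less compound is needed), compound 1 `CCOC(=O)N(C)CC#CCN1CCCC1` gives only a limit of the assay, > 100 mg/kg. Compound 2 `CCOC(=O)N(C)CC#CCn1ccnc1` likewise gives only a limit in this assay, > 100 mg/kg. The step that the two limits leave unreadable from compound 1 to compound 2 therefore cannot be read in size, although the change itself is clear: 1H-imidazol-1-yl in place of pyrrolidin-1-yl on a saturated chain carbon bound to a triple-bonded carbon. The limit of > 100 mg/kg in this assay, at which 2 of the 3 values shown sit, is where two of the three measured values sit. Going by the values given here, compound 3 `Cn1ccn(CC#CCN2CCCC2)c1=O` gives 6.6 mg/kg in this assay, the only number among the three; the difference between the core of compound 3 and the core of compound 1 is not broken down here. Compound 4 `Cn1ccn(CC#CCn2ccnc2)c1=O` has not yet been measured. It differs from compound 3 by 1H-imidazol-1-yl in place of pyrrolidin-1-yl on a saturated chain carbon bound to a triple-bonded carbon, the same change as from compound 1 to compound 2, made at the same place. That earlier step offers no size, so nothing measured tells how large the move should be; the expectation rests on compound 3 and its 6.6 mg/kg as the starting point. The account expects a step of a 3.8-fold higher number from compound 3 to compound 4 (0.58 log units; beyond the scatter) for compound 4 and estimates 25 mg/kg, between 6 mg/kg and 100 mg/kg, with a fair chance that only a limit is reported.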

Compound 4, dose for half-maximal effect: 3.7 mg/kg
Estimate against measurement, compound 4: 6.8-fold (0.83 log units) above, and the stated range ends above it.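

In this assay, on the core of compound 3, 1H-imidazol-1-yl in place of pyrrolidin-1-yl gives a 1.8-fold lower number from compound 3 to compound 4 (0.25 log units; within the scatter), so the two compounds cannot be told apart and pyrrolidin-1-yl is not required for a measurable dose on this core. The same change on the core of compound 1 cannot be read, since compound 1 and compound 2 both give only a limit of the assay and no size can be taken from them: the limit of > 100 mg/kg in this assay, at which 2 of the 4 values shown sit. The series therefore shows the outcome of this change on one core only and does not show whether that outcome carries over to the other, so no transfer from core to core is established.

On these data alone, it remains open what a different group on a saturated chain carbon bound to a triple-bonded carbon, such as a piperidin-1-yl ring or a dimethylamino group, would give on the core of compound 3. As far as these compounds go, it is equally open whether a longer chain carrying 1H-imidazol-1-yl would keep a measurable dose on that core.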